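Glycoside series: sugar exchange on the shared core

The source may report more compounds than this note shows. Statements on the series, on what has been measured and on what is new or still open speak of the compounds shown alone.

Measured so far:
- compound 1 `COc1cc([C@H]2Oc3c(OC)cc(CCCO)cc3[C@@H]2CO[C@@H]2O[C@@H](C)[C@H](O)[C@@H](O)[C@H]2O)cc(OC)c1O`: in a functional assay on SK-OV-3 cells (Homo sapiens) for cytotoxicity, read by sulforhodamine B assay (a higher number here means a weaker inhibitor, a lower number a stronger inhibitor), compound 1 gives > 10000 nM, a limit of the assay, not a number.
- compound 2 `COc1cc([C@H]2Oc3c(OC)cc(CCCO)cc3[C@@H]2CO[C@@H]2O[C@H](CO)[C@@H](O)[C@H](O)[C@H]2O)ccc1O`: in this assay compound 2 gives > 10000 nM, again a limit, not a number.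

Compound 2 therefore stands only at the limit; nothing about it is known beyond (the limit of > 10000 nM in this assay, at which 2 of the 2 values shown sit), and compound 1 sits at the same limit, so no ordering between the two can be read.

Compound 3 `COc1cc([C@H]2Oc3c(OC)cc(CCCO)cc3[C@@H]2CO[C@@H]2O[C@@H](C)[C@H](O)[C@@H](O)[C@H]2O)ccc1O` carries 3,4,5-trihydroxy-6-methyloxan-2-yl in place of 3,4,5-trihydroxy-6-(hydroxymethyl)oxan-2-yl on an oxygen on a saturated carbon. Compound 1 already bears the 3,4,5-trihydroxy-6-methyloxan-2-yl sugar on a different aryl part and reaches only a limit, so the sugar exchange is not expected to move compound 3 away from the limit; the step in this assay is expected to be none beyond the scatter, a step that the limit leaves unreadable from compound 2 to compound 3, most likely reported as a limit again.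

Compound 3 is expected at 20000 nM, within 8000 nM to 100000 nM.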

Compound 3, half-maximal inhibitory concentration: > 10000 nM
Compound 3: a limit, no number; the forecaster's own chance of this, stated with the estimate: 85%; the middle value is on the limit's open side.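

No step can be read among compound 1, compound 2 and compound 3, as each value is a limit and not a number: the limit of > 10000 nM in this assay, at which 3 of the 3 values shown sit.
The compounds shown leave open how the two sugars, or hydrogen and methoxy on the aromatic carbon, compare in this assay on the shared core.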